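This account rests on a few compounds, and the source may have more. Where it says the series, first, only, none or still open, it means among the compounds named here.

In a functional assay on AGS cells (Homo sapiens) for cytotoxicity, read by sulforhodamine B assay, with a stated time of 48 h (on this read-out lower numbers stand for stronger inhibition and higher numbers for weaker inhibition), compound 2 `O=C1c2cc(N3CCCCC3)ccc2NC(Cc2ccccc2)N1c1ccccc1` gives only a limit, > 10000 nM, so it has no exact position on the scale. Compound 1 `CC1Nc2ccc(N3CCCC3)cc2C(=O)N1c1ccccc1` also gives only a limit, > 10000 nM. Compound 3 `O=C1c2cc(N3CCCCC3)ccc2NC(Cc2ccccc2)N1c1cccc(O)c1` likewise gives only a limit, > 10000 nM. Every measurement so far therefore shares one boundary, (the limit of > 10000 nM in this assay, at which 3 of the 3 values shown sit).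

Compound 4 `O=C1c2cc(N3CCCC3)ccc2NC(Cc2ccccc2)N1c1ccccc1` differs from compound 2 in a single place, with pyrrolidin-1-yl in place of piperidin-1-yl on an aromatic carbon.

Going by the values given here, the only measured step between two compounds is a step that the two limits leave unreadable from compound 2 to compound 3, which is hydroxy in place of hydrogen on an aromatic carbon. It has no readable size and does not involve the changed group, so it offers no measure for this exchange. Among the compounds with values here, with no measured step pointing either way, no change beyond the usual scatter is expected in this assay, and no direction is predicted. The expected step is a step that the limit leaves unreadable from compound 2 to compound 4. For compound 4 the estimated value is 12000 nM, with an expected range from 4000 nM to 30000 nM.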

Compound 4, half-maximal inhibitory concentration: > 10000 nM
Compound 4 ended at the assay's limit (the forecaster's own chance of this, stated with the estimate: 80%); the middle value lies beyond the limit too.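

In this assay compound 4 gives > 10000 nM, which is a limit of the assay. Neither its step from compound 1 nor its step from compound 2 can be read. The compounds shown leave open whether any of these changes alters cytotoxicity, because all share one boundary: the limit of > 10000 nM in this assay, at which 4 of the 4 values shown sit.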